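Bromo Substitution and Vero Cell Cytotoxicity in Two Series

The compounds below may be only part of what the source reports. "The series", "measured", "known", "first", "only" and "open" are said of these compounds alone.

Compound 1, `CC(=O)C[C@H]1O[C@@H](On2cc(CN3C(=O)/C(=N\Nc4ccccc4)c4ccccc43)nn2)[C@H](OC(C)=O)[C@@H](OC(C)=O)[C@@H]1OC(C)=O`: 108000 nM
Compound 2, `CC(=O)C[C@H]1O[C@@H](On2cc(CN3C(=O)/C(=N\Nc4ccc(Br)cc4)c4ccccc43)nn2)[C@H](OC(C)=O)[C@@H](OC(C)=O)[C@@H]1OC(C)=O`: 116000 nM
Compound 3, `CC1(C)O[C@H]2O[C@H](Cn3cc(CN4C(=O)/C(=N\Nc5ccccc5)c5ccccc54)nn3)[C@H](O)[C@H]2O1`: 82100 nM

In an ADME assay on Vero cells (Chlorocebus sabaeus) for cytotoxicity, read by fluorescence and resazurin assay, with a stated time of 3 days (on this read-out lower numbers stand for higher toxicity in this test and higher numbers for lower toxicity in this test), compound 1 gives 108000 nM, compound 2 gives 116000 nM and compound 3 gives 82100 nM. The three values lie close together. Compound 1 and compound 2 differ in one place, (bromo in place of hydrogen on an aromatic carbon), and this change gave a 1.1-fold higher number from compound 1 to compound 2 (0.03 log units; within the scatter). Compound 4, `CC1(C)O[C@H]2O[C@H](Cn3cc(CN4C(=O)/C(=N\Nc5ccc(Br)cc5)c5ccccc54)nn3)[C@H](O)[C@H]2O1`, carries the same kind of change on the core of compound 3, (bromo in place of hydrogen on an aromatic carbon), with the place described in the same words in both pairs. The difference between the two cores is not broken down here. Because a 1.1-fold higher number from compound 1 to compound 2 (0.03 log units; within the scatter) stayed within the scatter, the expected step in this assay is a 1.1-fold higher number from compound 3 to compound 4 (0.03 log units; within the scatter). Compound 4 is therefore estimated at 88000 nM, most likely between 45000 nM and 170000 nM.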

Compound 4, half-maximal cytotoxic concentration: 72900 nM
Compound 4: middle estimate off by 1.2-fold (0.08 log units), on the high side, within the range that was stated.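

In this assay, the bromo change gave a 1.1-fold lower number from compound 3 to compound 4 (0.05 log units; within the scatter). Set beside the earlier step, the two results do not differ: the same change on two cores in this assay, a 1.1-fold higher number (0.03 log units; within the scatter) from compound 1 to compound 2 and a 1.1-fold lower number (0.05 log units; within the scatter) from compound 3 to compound 4, 1.2-fold (0.08 log units) apart, within the scatter of two such steps. This shows that phenyl to 4-bromophenyl left the number within the scatter on both cores, so the step carried over in these two pairs, but two pairs of low toxicity in this test do not show that the same would hold on any other core.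

The compounds shown leave open what a fluoro group, a methoxy group, an amine or a carboxylic acid in the place of the bromo would do in this assay on either core. Also open, from the compounds shown here alone, is what the difference between the two cores itself contributes.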